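The source may hold more compounds than are shown below. What is called first, only, known or untested is meant among the compounds shown, and "the series" means these compounds.

Compounds measured in a functional assay on HeLa cells (Homo sapiens) for inhibition, read by MTT assay, with a stated time of 72 h; on this read-out higher numbers stand for weaker inhibition and lower numbers for stronger inhibition:
compound 1, `COc1cc(NC(C)CCCNC(=O)NNC(=O)Nc2cccc(F)c2)c2ncccc2c1`, limit: > 250000 nM
compound 2, `COc1cc(NC(C)CCCNC(=O)Nc2ccc(O)cc2)c2ncccc2c1`, 70000 nM
compound 3, `COc1cc(NC(C)CCCNC(=O)NNC(=O)Nc2cccc(C(F)(F)F)c2)c2ncccc2c1`, 4900 nM

In this assay compound 1 reaches only a limit, > 250000 nM, and gives no number. Compound 2 gives 70000 nM, and compound 3 gives 4900 nM. Of the two numbers shown, compound 3 stands lowest, compound 2 being the nearest at a gap well beyond the scatter; the value of compound 1 is a limit.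

Two steps are known. From compound 1 to compound 3 the change is an at least 51-fold lower number from compound 1 to compound 3 (1.70 log units; beyond the scatter), a large step that stems from trifluoromethyl in place of fluoro on an aromatic carbon. From compound 1 to compound 2 the change is an at least 3.5-fold lower number from compound 1 to compound 2 (0.55 log units; beyond the scatter), where 4-hydroxyphenyl replaces ((3-fluorophenyl)carbamoyl)amino on an amide-type nitrogen, so that both the linker and the aryl group change at once.

Compound 4, `COc1cc(NC(C)CCCNC(=O)NNC(=O)Nc2ccc(O)cc2)c2ncccc2c1`, is not yet measured. It differs from compound 3 by 4-hydroxyphenyl in place of 3-(trifluoromethyl)phenyl on an amide-type nitrogen. The step from compound 1 to compound 3 shows that the group on this aryl ring weighs heavily, and compound 2, which carries 4-hydroxyphenyl on a shorter linker, sits at 70000 nM. Compound 4 is therefore expected to give a clearly higher number than compound 3, a step of about a 12-fold higher number from compound 3 to compound 4 (1.09 log units; beyond the scatter). The estimate for compound 4 is 60000 nM, within a range from 12000 nM to 250000 nM.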

Compound 4, half-maximal inhibitory concentration: 85000 nM
Compound 4: the middle estimate sits 1.4-fold (0.15 log units) below what was measured; the range from low to high includes it.
By their numbers in this assay, from the lowest: compound 3; then compounds 2 and 4 (each within the scatter of the next). At a limit, above all of these: compound 1.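

In this assay, the change of aryl group on this amide-type nitrogen gives a 17-fold higher number from compound 3 to compound 4 (1.24 log units; beyond the scatter), whereas ((4-hydroxyphenyl)carbamoyl)amino in place of 4-hydroxyphenyl gives only a 1.2-fold higher number from compound 2 to compound 4 (0.08 log units; within the scatter), so with a 4-hydroxyphenyl group the two linkers cannot be told apart. Against the 3-fluorophenyl group, the same 4-hydroxyphenyl group gives an at least 2.9-fold lower number from compound 1 to compound 4 (0.46 log units; beyond the scatter), which leaves 3-(trifluoromethyl)phenyl as the aryl group that sets compound 3 apart among the three carried on this linker. Compound 1 gives only a limit, so its step is a bound and not a measured size: the limit of > 250000 nM in this assay, at which 1 of the 4 values shown sits.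

The compounds shown leave open whether the group or its place on the ring counts, since both change together from compound 3 to compound 4, and a 4-(trifluoromethyl)phenyl or a 3-hydroxyphenyl group would separate the two. They also leave open how 3-(trifluoromethyl)phenyl would read on the shorter linker of compound 2, and how an aryl ring carrying an amine or a carboxylic acid would compare on either linker.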